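The source may hold more compounds than are shown below. What is called first, only, known or untested is meant among the compounds shown, and "the series" means these compounds.

Working notes on the series. Compound 1 `COc1ccc(C2=NO[C@]3(C2)C(=O)O[C@@H]2[C@H]3CC[C@H](C)[C@]3(O)C=CC(=O)[C@@]23C)cc1OC` gives 1.06 in a physicochemical assay for lipophilicity; a lower number here means a more polar compound, a higher number a more lipophilic compound. Compound 2 `Cc1ccc(C2=NO[C@]3(C2)C(=O)O[C@@H]2[C@H]3CC[C@H](C)[C@]3(O)C=CC(=O)[C@@]23C)cc1` gives 1.86; the step of a number 0.80 log units higher from compound 1 to compound 2 (beyond the scatter) is the only one so far in which an aryl group on the shared core is exchanged. Compound 3 `C[C@H]1CC[C@@H]2[C@@H](OC(=O)[C@]23CC(c2ccc(C#N)cc2)N(c2ccccc2)O3)[C@]2(C)C(=O)C=C[C@@]12O` gives 2.94, the highest of the three numbers; compound 2 stands nearest to it and compound 1 furthest, both lower by more than the scatter.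

Compound 4 `C[C@H]1CC[C@@H]2[C@@H](OC(=O)[C@]23CC(c2c(F)c(F)c(F)c(F)c2F)N(c2ccccc2)O3)[C@]2(C)C(=O)C=C[C@@]12O` differs from compound 3 in one place: 2,3,4,5,6-pentafluorophenyl in place of 4-cyanophenyl on a saturated ring carbon. The step of a number 0.80 log units higher from compound 1 to compound 2 (beyond the scatter) bears on this only loosely, since it concerns a different carbon and other groups, so it sets no more than a rough size. A rise beyond the scatter is expected for compound 4, as a number 1.16 log units higher from compound 3 to compound 4 (beyond the scatter). Compound 4 is estimated at 4.1, with a range from 3.4 to 4.8.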

Compound 4, partition coefficient: 3.72
The estimate for compound 4 lay 0.38 log units above the measured number, and the stated range covers the measured number.
By their numbers in this assay, from the lowest: compound 1; then compound 2; then compound 3; then compound 4.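

In this assay, the aryl group on the saturated ring carbon also changes the reading, with a number 0.78 log units higher from compound 3 to compound 4 (beyond the scatter), when 2,3,4,5,6-pentafluorophenyl replaces 4-cyanophenyl. For the compounds shown here, the earlier step concerned a carbon with a double bond to nitrogen, so this is the first aryl exchange read at this position. No supporting measurement accounts for the size of this step.

Still open, on these data alone, is how a 4-aminophenyl or 4-carboxyphenyl group would read on this carbon. Also open, as far as these compounds go, is whether the pentafluorophenyl exchange would give a similar step on the carbon with a double bond to nitrogen.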